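Replacing the acetylphenyl group with a methylindolyl group

The compounds below may be only part of what the source reports. "The series", "measured", "known", "first", "only" and "open" are said of these compounds alone.

Of the compounds shown here, three sharing one core have been measured. Compound 3 `COc1cc(-c2ccnc3cc(-c4ccc(C(C)=O)cc4)nn23)cc(OC)c1OC` carries a 4-acetylphenyl group on the fused five-membered ring, and in a functional assay on HCT-116 cells (Homo sapiens) for inhibition, read by CCK-8 assay, with a stated time of 48 h (a higher number here means a weaker inhibitor, a lower number a stronger inhibitor), compound 3 gives 4390 nM. That is the highest of the three numbers. Compound 2 `COc1cc(-c2ccnc3cc(-c4ccc(Cl)cc4)nn23)cc(OC)c1OC` gives 3340 nM, and the step of a 1.3-fold higher number from compound 2 to compound 3 (0.12 log units; within the scatter) is small, so these two compounds cannot be ordered. Compound 1 `COc1cc(-c2ccnc3cc(-c4ccc(C)cc4)nn23)cc(OC)c1OC` gives 48 nM, and the step of a 91-fold higher number from compound 1 to compound 3 (1.96 log units; beyond the scatter) is large; likewise a 70-fold higher number from compound 1 to compound 2 (1.84 log units; beyond the scatter).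

Compound 4 `COc1cc(-c2ccnc3cc(-c4ccc5ccn(C)c5c4)nn23)cc(OC)c1OC` has not yet been measured. 1-methyl-1H-indol-6-yl in place of 4-acetylphenyl on an aromatic carbon No measured step covers the 1-methyl-1H-indol-6-yl group, so the expectation rests only on the steps shown. The acetyl-bearing ring of compound 3 and the chloro-bearing ring of compound 2 gave the two high numbers, and the methyl-bearing ring of compound 1 gave the low one, because a 91-fold higher number from compound 1 to compound 3 (1.96 log units; beyond the scatter) and a 70-fold higher number from compound 1 to compound 2 (1.84 log units; beyond the scatter) were both large. Removing the acetyl group is therefore expected to lower the number, though by how much is uncertain. Compound 4 is estimated to give 400 nM, within a range from 50 nM to 3500 nM. The expected step is an 11-fold lower number from compound 3 to compound 4 (1.04 log units; beyond the scatter).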

Compound 4, half-maximal inhibitory concentration: 1040 nM
Compound 4: middle estimate off by 2.6-fold (0.41 log units), on the low side, and the stated range covers the measured number.
By their numbers in this assay, from the lowest: compound 1; then compound 4; then compounds 2 and 3 (each within the scatter of the next).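

Compound 4 shows that this carbon of the five-membered aromatic ring, two ring bonds from the ring nitrogen, can carry a group of two fused aromatic rings and still give a number in this assay that stands apart from the two high numbers (a 4.2-fold lower number from compound 3 to compound 4 (0.63 log units; beyond the scatter); a 3.2-fold lower number from compound 2 to compound 4 (0.51 log units; beyond the scatter)). Both of these steps are modest, however, and the 1-methyl-1H-indol-6-yl group remains well short of the 4-methylphenyl group (a 22-fold higher number from compound 1 to compound 4 (1.34 log units; beyond the scatter)), a large step. Going by these compounds alone, the earlier compounds gave only one low number and a pair of high numbers that could not be ordered, whereas the four compounds now show an intermediate level, with compound 4 lying beyond the scatter of all three others. Nothing among the data presented explains why the groups fall in this order.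

The compounds shown leave open whether an ethyl group, a longer chain, an amine or a carboxylic acid in place of the methyl of compound 1 would keep its low number. They also leave open how the 1H-indol-6-yl group without its methyl would compare with compound 4.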